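Ring stereocentre inversion in the sulfonamide amide series

A few compounds are considered here, and "the series" means these few. Any claim that something is new, unique, unknown or untested is made for them only; others in the source may bear on it.

Measured so far:
compound 1 `O=C(CC(NS(=O)(=O)c1ccc2ccccc2c1)c1ccccc1)NCc1ccc(CN2CCCCC2)cc1` — 359 nM
compound 2 `O=C(C[C@@H](NS(=O)(=O)c1ccc2ccccc2c1)c1ccccc1)NCc1ccc(CN2CCCCC2)cc1` — 447 nM
compound 3 `CN1c2cc(CN3CCCCC3)ccc2[C@H](NC(=O)C[C@@H](NS(=O)(=O)c2ccc3ccccc3c2)c2ccccc2)CS1(=O)=O` — 14 nM

Compound 3 has the lowest number of the three in a functional assay on CHO cells for antagonist activity at B1 bradykinin receptor (Homo sapiens), read by calcium flux; a higher number here means a weaker inhibitor, a lower number a stronger inhibitor; compound 1 sits closest to it and compound 2 furthest, both beyond the scatter. Among the compounds with values here, the one step measured within one change, a 1.2-fold higher number from compound 1 to compound 2 (0.10 log units; within the scatter), concerns the chain stereocentre only, and it stays within the scatter; what sets compound 1 apart from compound 2 is the fact that one of compounds 1 and 2 is drawn with a defined configuration and the other without, at the place where they differ, so this step says little about the effect of a defined configuration at that chain carbon.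

Compound 4 `CN1c2cc(CN3CCCCC3)ccc2[C@@H](NC(=O)C[C@@H](NS(=O)(=O)c2ccc3ccccc3c2)c2ccccc2)CS1(=O)=O` is not yet measured. It differs from compound 3 as follows: the two compounds have the same atoms and bonds and differ only in configuration as drawn: 1 of 2 stereo elements differ; a stereocentre at a saturated ring carbon is drawn S in compound 3 and R in compound 4. Within the data shown here, no measured step touches that ring stereocentre, so the step from compound 1 to compound 2 bears on it only by analogy, and that one was small. A change of configuration at a single ring carbon in an otherwise identical molecule can move the number well beyond the scatter in either direction, and the most common outcome for the epimer of the stronger isomer is a weaker result.

Compound 4 is therefore expected to show a higher number than compound 3, a 6.4-fold higher number from compound 3 to compound 4 (0.81 log units; beyond the scatter). In this assay compound 4 is estimated at 90 nM, in a range from 15 nM to 600 nM.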

Compound 4, half-maximal inhibitory concentration: 10.7 nM
Compound 4: the middle estimate sits 8.4-fold (0.92 log units) above what was measured, and the stated range ends above it.
By their numbers in this assay, from the lowest: compounds 4 and 3 (each within the scatter of the next); then compounds 1 and 2 (each within the scatter of the next).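

In this assay, within the data shown here, inverting the saturated ring carbon from S to R gives a 1.3-fold lower number from compound 3 to compound 4 (0.12 log units; within the scatter), the first direct reading at this ring stereocentre. The earlier step concerned only the chain stereocentre, with one partner drawn without a configuration, so it could not show what a defined inversion does; this pair has a defined configuration on each side of the change, and the comparison has a single variable: the fact that compounds 3 and 4 differ only in the configuration as drawn. For this pair, the configuration at the ring carbon does not separate the two numbers, and neither isomer can be ranked above the other, though that reading holds only for this one pair and says nothing about other substitution on the core.

Among these compounds, still open is what the opposite configuration at the chain carbon would do on this core, since compound 3 and compound 4 share one drawn configuration there, so the chain stereocentre has no defined pair of its own. Also open, from the compounds shown here alone, is whether the ring carbon stays this indifferent when a carboxylic acid or an open-chain amine such as dimethylamine takes the place of the ring amine.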